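Cyclopropylmethyl ether at the aryl oxygen of the shared core

The source may hold more compounds than are shown below. What is called first, only, known or untested is meant among the compounds shown, and "the series" means these compounds.

Measured compounds:
compound 1 `CCOCC(C)Oc1cccc2ccc(N)nc12`: 1070 nM
compound 2 `Nc1ccc2cccc(OCC3CCOC3)c2n1`: 115 nM
compound 3 `CCCOc1cccc2ccc(N)nc12`: 1100 nM

In an assay on cells with melanin-concentrating hormone receptor 1 (Homo sapiens) as the target, read by radioligand binding (on this read-out lower numbers stand for stronger inhibition and higher numbers for weaker inhibition), compound 1 gives 1070 nM, the second highest of the three numbers, and compound 3 sits within the scatter of it: a 1.0-fold higher number from compound 1 to compound 3 (0.01 log units; within the scatter). Compound 2 stands apart, with a 9.3-fold lower number from compound 1 to compound 2 (0.97 log units; beyond the scatter); the same pattern shows in a 9.6-fold higher number from compound 2 to compound 3 (0.98 log units; beyond the scatter). Among these three, only compound 2 carries a ring on the chain at the aryl oxygen, and only compound 2 gives a number below the other two beyond the scatter.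

Compound 4 `Nc1ccc2cccc(OCC3CC3)c2n1` has not yet been measured. The change from compound 1 is a group of 4 heavy atoms (4 carbon; one three-membered non-aromatic ring of carbon only) in place of a group of 6 heavy atoms (5 carbon, 1 oxygen; no ring), on an oxygen on an aromatic ring. The step to compound 2 is the one that bears on it, since a ring enters there as well, but the group entering in compound 4 is smaller and carries no hydrogen-bond acceptor, unlike oxolan-3-ylmethyl. The account therefore expects a step in this assay that is lower in number yet smaller than a 9.3-fold lower number from compound 1 to compound 2 (0.97 log units; beyond the scatter). The expected step is a 3.1-fold lower number from compound 1 to compound 4 (0.49 log units; beyond the scatter). Compound 4 is estimated at 350 nM, with a range from 110 nM to 1200 nM.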

Compound 4, half-maximal inhibitory concentration: > 2000 nM
Compound 4: a limit, no number (the forecaster's own chance of this, stated with the estimate: 3%); middle value at least 5.7-fold (0.75 log units) away from the limit.
By their numbers in this assay, from the lowest: compound 2; then compounds 1 and 3 (each within the scatter of the next). At a limit, above all of these: compound 4.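

In this assay compound 4 gives > 2000 nM, which is a limit of the assay and not a number. Against the two open-chain compounds this limit settles little, since it reads only as an at least 1.8-fold higher number from compound 1 to compound 4 (0.27 log units; that floor lies within the scatter) and as an at least 1.8-fold higher number from compound 3 to compound 4 (0.25 log units; that floor lies within the scatter). Against compound 2 it is clear, at an at least 17-fold higher number from compound 2 to compound 4 (1.24 log units; beyond the scatter), so compound 4 goes against the earlier pattern: a ring on the chain on an oxygen on an aromatic ring does not in itself bring the low number, and cyclopropyl in place of oxolan-3-yl does not keep it.

The compounds shown leave open whether the ring oxygen of compound 2 or the size of its ring sets this gap, a question that a cyclopentylmethyl group at the same place would bear on. On these data alone, how far compound 4 lies beyond its limit also stays open.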